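A few compounds are considered here, and "the series" means these few. Any claim that something is new, unique, unknown or untested is made for them only; others in the source may bear on it.

Measured in a functional assay on the whole organism (stomach) with Rattus norvegicus as the target; a higher number here means that more compound is needed for the effect, a lower number that less compound is needed:
- compound 1 `CCCCCCCC/N=C/N1CCC(C(c2ccccc2)c2ccccc2)CC1` gives 0.6 mg/kg
- compound 2 `CC(=O)CCCCCC/N=C/N1CCC(C(c2ccccc2)c2ccccc2)CC1` gives 1.5 mg/kg

Not yet measured:
- compound 3 `CCCCCCCC/N=C/N1CCC(C(c2ccccc2)c2ccc(O)cc2)CC1`

Compound 1 has the lower of the two numbers in this assay and so needs less compound for the effect than compound 2. Compound 3 keeps the octyl-bearing core of compound 1 and changes phenyl to 4-hydroxyphenyl on one side (hydroxy in place of hydrogen on an aromatic carbon). Among the measured compounds shown here, no measured step touches an aromatic carbon. For the measured compounds named here, the only measured step (acetyl in place of ethyl on a saturated chain carbon) is a 2.5-fold higher number from compound 1 to compound 2 (0.40 log units; beyond the scatter) and bears on this change only indirectly. It gives a rough size, not a firm direction. A modest move towards a higher number is therefore expected, and the expected step is a 2.5-fold higher number from compound 1 to compound 3 (0.40 log units; beyond the scatter) with low confidence. The estimate for compound 3 is 1.5 mg/kg (expected range 0.4 mg/kg to 5 mg/kg).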

Compound 3, dose for half-maximal effect: 3.1 mg/kg
Beside the measured number, compound 3's estimate is 2.1-fold (0.32 log units) below it; the range from low to high includes it.
By their numbers in this assay, from the lowest: compound 1; then compound 2; then compound 3.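

In this assay, hydroxy in place of hydrogen on an aromatic carbon, para to a large group, gives a 5.2-fold higher number from compound 1 to compound 3 (0.71 log units; beyond the scatter). The earlier compounds shown here differed only in the chain, whereas this result shows that the number also responds to a change on the aromatic part of the core of compound 1, with a single added hydroxy moving it towards more compound being needed. Nothing available on the compounds accounts for this step.

On these data alone, whether the higher number is specific to hydroxy remains open, since methoxy, fluorine or an amine in the same place would separate this group from other substituents. Also open, as far as these compounds go, is whether phenyl to 4-hydroxyphenyl has a similar effect when the chain carries the acetyl group of compound 2.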